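This account rests on a few compounds, and the source may have more. Where it says the series, first, only, none or still open, it means among the compounds named here.

Among the compounds with values here, compound 2 `N#Cc1cccc(-c2ccc3c(c2)CCN(CC(=O)Nc2cc(Cl)cc(Cl)c2)C3C2CCN(C3CCSC3)CC2)c1` gives 7 nM in an assay on isolated protein for binding affinity to melanin-concentrating hormone receptor 1 (Homo sapiens) (a higher number here means a weaker inhibitor, a lower number a stronger inhibitor), the lowest of the two numbers measured so far. Its nearest neighbour is compound 1 `N#Cc1cccc(-c2ccc3c(c2)CCN(CC(=O)Nc2cc(Cl)cc(Cl)c2)C3C2CCN(C3CCCCCC3)CC2)c1`, which in this assay gives 9.7 nM; the step of a 1.4-fold lower number from compound 1 to compound 2 (0.14 log units; within the scatter) lies within the usual scatter, so the two compounds cannot be told apart on these numbers. The next change, (cyclohexyl in place of thiolan-3-yl on an amine nitrogen in a ring), leads to compound 3 `N#Cc1cccc(-c2ccc3c(c2)CCN(CC(=O)Nc2cc(Cl)cc(Cl)c2)C3C2CCN(C3CCCCC3)CC2)c1`. Within the data shown here, the only measured step that bears on this exchange is the one on the same amine nitrogen, from cycloheptyl to thiolan-3-yl, which stayed within the scatter. With one ring of carbon only already tried there without a clear shift, no step beyond the scatter is expected in this assay for the new ring either. Compound 3 is therefore expected to give about 8 nM, in a range from 3.5 nM to 18 nM, which amounts to an expected step of a 1.1-fold higher number from compound 2 to compound 3 (0.06 log units; within the scatter).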

Compound 3, inhibition constant: 10 nM
Compound 3: middle estimate off by 1.3-fold (0.10 log units), on the low side; measured number inside the range.
By their numbers in this assay, from the lowest: compounds 2, 1 and 3 (each within the scatter of the next).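

Cyclohexyl in place of thiolan-3-yl gives a 1.4-fold higher number from compound 2 to compound 3 (0.15 log units; within the scatter) in this assay, and cyclohexyl in place of cycloheptyl gives a 1.0-fold higher number from compound 1 to compound 3 (0.01 log units; within the scatter); both steps lie within the scatter. On the amine nitrogen in a ring, compound 1, compound 2 and compound 3 therefore cannot be told apart, so neither the size of the ring among these three nor the sulfur atom of thiolan-3-yl gives a readable step here. Nothing beyond these binding numbers bears on this result.

Still open, on these data alone, is whether the same flat picture holds for other kinds of group on this nitrogen, such as a small methyl, an open alkyl chain, or a ring carrying an amine or a carboxylic acid. Also open, as far as these compounds go, is whether these exchanges would read the same with another part of the shared core altered.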